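A Larger Group on the Double-Bonded Nitrogen of Compound 3

The source may report more compounds than this note shows. Statements on the series, on what has been measured and on what is new or still open speak of the compounds shown alone.

Three compounds share one core and differ only in the group on a saturated chain carbon bound to an amine nitrogen in a ring. In an ADME assay on Vero cells (Chlorocebus sabaeus) for cytotoxicity, read by MTT assay, with a stated time of 72 h (a lower number here means that less compound is tolerated, a higher number that more compound is tolerated), compound 1 `COc1c(N2CCN(CC#N)C(C)C2)c(F)cc2c(=O)c(C(=O)O)cn(C3CC3)c12` gives 354 ug/mL, compound 2 `CCOC(=O)CN1CCN(c2c(F)cc3c(=O)c(C(=O)O)cn(C4CC4)c3c2OC)CC1C` gives 1000 ug/mL, and compound 3 `CCO/N=C(\C)CN1CCN(c2c(F)cc3c(=O)c(C(=O)O)cn(C4CC4)c3c2OC)CC1C` gives 31.3 ug/mL. Compound 3 therefore stands lowest of the three, with an 11-fold lower number from compound 1 to compound 3 (1.05 log units; beyond the scatter) and a 32-fold lower number from compound 2 to compound 3 (1.50 log units; beyond the scatter), both large. The remaining pair is closer, with a 2.8-fold higher number from compound 1 to compound 2 (0.45 log units; beyond the scatter), a modest step.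

Compound 4 `COc1c(N2CCN(C/C(C)=N/NC(=O)c3ccncc3)C(C)C2)c(F)cc2c(=O)c(C(=O)O)cn(C3CC3)c12` carries ((pyridin-4-yl)carbonyl)amino in place of ethoxy on a double-bonded nitrogen. Within the data shown here, no measured step makes this exchange, so the three steps bear on it only indirectly: each replaces the whole group on the chain carbon. They show that changes in this chain can shift the number considerably. The expectation of a rise rests on compound 3 lying at the low end with 31.3 ug/mL, reached through the large 32-fold lower number from compound 2 to compound 3 (1.50 log units; beyond the scatter), and on the loss of its ethoxy. Among the measured compounds shown here, this is weak support, since no measured compound carries such a ring in the chain. A modest rise is expected, an estimated 3.2-fold higher number from compound 3 to compound 4 (0.50 log units; beyond the scatter). For compound 4 the estimate in this assay is 100 ug/mL, with an expected range from 30 ug/mL to 330 ug/mL.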

Compound 4, half-maximal cytotoxic concentration: 250 ug/mL
Beside the measured number, compound 4's estimate is 2.5-fold (0.40 log units) below it; the measured number falls inside the stated range.
By their numbers in this assay, from the lowest: compound 3; then compounds 4 and 1 (each within the scatter of the next); then compound 2.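

In this assay, among these compounds, ((pyridin-4-yl)carbonyl)amino in place of ethoxy on a double-bonded nitrogen gives the first step that keeps the carbon with a double bond to nitrogen and changes only what that nitrogen carries (an 8.0-fold higher number from compound 3 to compound 4 (0.90 log units; beyond the scatter)), so the double bond alone does not set the low number of compound 3. Against the chain ending in a nitrile, the group of 12 heavy atoms on the saturated chain carbon cannot be told apart (a 1.4-fold lower number from compound 1 to compound 4 (0.15 log units; within the scatter)), while the chain ending in ethoxycarbonyl stands clear of it (a 4.0-fold lower number from compound 2 to compound 4 (0.60 log units; beyond the scatter)). Heavy-atom count does not order these numbers: compound 4 carries the largest group, yet compound 3, with its group of 6 heavy atoms, stands lowest, and compound 1, with the smallest group, lies within the scatter of compound 4.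

As far as these compounds go, it remains open whether the rise follows the six-membered aromatic ring, the carbonyl or the amide hydrogen. A plain phenyl ring, a simple amine or a carboxylic acid on the double-bonded nitrogen could separate these parts. Nothing shown here gives a measured reason for any of these differences.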